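A few compounds are considered here, and "the series" means these few. Any claim that something is new, unique, unknown or untested is made for them only; others in the source may bear on it.

For the measured compounds named here, compound 1 `COc1ccc(-c2[nH]c3ccccc3c2/C=C(\C#N)S(=O)(=O)c2ccccc2)cc1` is one of two compounds measured in a functional assay on SW-620 cells (Homo sapiens) for inhibition, read by sulforhodamine B assay, with a stated time of 48 h; on this read-out higher numbers stand for weaker inhibition of growth and lower numbers for stronger inhibition of growth. In this assay compound 1 gives 506 nM, the lowest of the two numbers on hand, though compound 2 `COc1ccc(-c2[nH]c3ccc(OC)cc3c2C=C(C#N)C#N)cc1`, which gives 579 nM, lies within the scatter of it. Compound 3 `N#C/C(=C\c1c(-c2ccccc2)[nH]c2ccccc12)S(=O)(=O)c1ccccc1` is not yet measured. It differs from compound 1 by hydrogen in place of methoxy on an aromatic carbon. Going by the values given here, no measured pair shows this change, so only a small step is expected, leaning toward a higher number but possibly none beyond the scatter. For compound 3 the expected value in this assay is 750 nM, ranging from 250 nM to 2200 nM. This estimate means an expected step of a 1.5-fold higher number from compound 1 to compound 3 (0.17 log units; within the scatter).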

Compound 3, concentration for 50% growth inhibition: 570 nM
Compound 3: the middle estimate sits 1.3-fold (0.12 log units) above what was measured; measured number inside the range.
By their numbers in this assay, from the lowest: compounds 1, 3 and 2 (each within the scatter of the next).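

In this assay, going from 4-methoxyphenyl to phenyl gives a 1.1-fold higher number from compound 1 to compound 3 (0.05 log units; within the scatter), so at this position the read-out does not separate methoxy from hydrogen. The methoxy on this aromatic carbon is therefore not required for growth inhibition at this level on the core of compound 1. Nothing on hand gives a reason for this result. What the compounds leave open is whether an amine, a carboxylic acid or a longer alkoxy chain on this aromatic carbon would shift the number beyond the scatter.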